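Cytotoxicity notes on the shared-core series

The source may hold more compounds than are shown below. What is called first, only, known or untested is meant among the compounds shown, and "the series" means these compounds.

Compound 1 `Cc1nc(-c2cccnc2)sc1-c1nnc(-c2cccnc2)o1` in an ADME assay on THP-1 cells (Homo sapiens) for cytotoxicity, read by MTT assay (a higher number here means that more compound is tolerated, a lower number that less compound is tolerated), gives > 100 ug/mL, which is a limit of the assay.
Compound 2 `Cc1nc(-c2cccnc2)sc1-c1nnc(-c2ccc(Cl)cc2)o1` in this assay gives > 100 ug/mL, also a limit.
Compound 3 `Cc1nc(-c2cccnc2)sc1-c1nnc(-c2ccccc2Cl)o1` in this assay gives > 100 ug/mL, also a limit.

Compound 1 stands only as a limit, as do the two other values shown (the limit of > 100 ug/mL in this assay, at which 3 of the 3 values shown sit). The step to compound 4 `Cc1nc(-c2cccnc2)sc1-c1nnc(-c2ccc(O)cc2)o1` is 4-hydroxyphenyl in place of pyridin-3-yl on an aromatic carbon. The measured steps at the same position, a step that the two limits leave unreadable from compound 1 to compound 2 and a step that the two limits leave unreadable from compound 1 to compound 3, cannot be sized, and the same holds for a step that the two limits leave unreadable from compound 2 to compound 3. No readable step is available in this assay, so no direction can be given for the change to compound 4; what the three measured compounds show is that each aryl variant at this position has sat at the limit. Compound 4 is therefore expected to remain at the limit as well, with an estimated a number no higher from compound 1 to compound 4 (the limit leaves the size open) of no readable size. The estimate for compound 4 is 100 ug/mL, within 50 ug/mL to 200 ug/mL.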

Compound 4, half-maximal cytotoxic concentration: > 100 ug/mL
Compound 4: no number, only a limit (the forecaster's own chance of this, stated with the estimate: 80%); the middle value lies on the limit itself.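

No step can be read between compound 4 and compound 1, compound 2 or compound 3 in this assay, as all four sit at the same limit: the limit of > 100 ug/mL in this assay, at which 4 of the 4 values shown sit.

The compounds shown leave open the actual half-maximal cytotoxic concentration of each of the four, and whether any of them differs from another.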